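This account rests on a few compounds, and the source may have more. Where it says the series, first, only, none or still open, it means among the compounds named here.

Working notes on a small set of compounds followed in a functional assay on the whole organism (strain albino) for inhibition, with Rattus norvegicus as the target, read by paw edema, with a stated time of 3 h, at a dose of 0.28 mmol/kg by the oral route; on this read-out lower numbers stand for less inhibition and higher numbers for more inhibition at the one dose given (going by the name of the read-out).

Compound 1 is `CCn1c(SCC(=O)c2ccccc2)nnc1-c1ccc(OC)cc1`; in this assay compound 1 gives 67%. Compound 2 is `C=CCn1c(SCC(=O)c2ccccc2)nnc1-c1ccc(OC)cc1`; in this assay compound 2 gives 63%. The change from compound 1 to compound 2 is vinyl in place of methyl on a saturated chain carbon bound to an aromatic nitrogen, and the step it made is a number 4 percentage points lower from compound 1 to compound 2 (within the scatter), so the two values cannot be told apart.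

Compound 3 is `CCn1c(SC/C(=N/O)c2ccccc2)nnc1-c1cc(OC)c(OC)c(OC)c1`; in this assay compound 3 gives 69%. The difference between the core of compound 1 and the core of compound 3 is not broken down here. The value of compound 3 sits within the scatter of the value of compound 1 and within the scatter of the value of compound 2, so no ordering among the three is claimed.

Compound 4 is `C=CCn1c(SC/C(=N/O)c2ccccc2)nnc1-c1cc(OC)c(OC)c(OC)c1` and has not yet been measured in this assay. Its difference from compound 3 is vinyl in place of methyl on a saturated chain carbon bound to an aromatic nitrogen, the same place and the same groups as the change from compound 1 to compound 2; it is therefore the same change, carried out on the other core. This change occurs twice among the compounds shown.

Among the compounds with values here, because the only measured instance of this change, a number 4 percentage points lower from compound 1 to compound 2 (within the scatter), lies within the scatter, the step from compound 3 to compound 4 is expected to be of the same small size, estimated as a number 4 percentage points lower from compound 3 to compound 4 (within the scatter). For compound 4 the value in this assay is estimated at 65%, expected to fall between 54% and 76%.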

Compound 4, a percentage reported as inhibition, in the whole organism at one dose (the size of the read-out at that dose, not a potency): 70%
The estimate for compound 4 lay 5 percentage points below the measured number; the measured number falls inside the stated range.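

The new step, a number 1 percentage points higher from compound 3 to compound 4 (within the scatter), can be set beside the earlier one in this assay: the same change on two cores in this assay, a number 4 percentage points lower (within the scatter) from compound 1 to compound 2 and a number 1 percentage points higher (within the scatter) from compound 3 to compound 4, 5 percentage points apart, within the scatter of two such steps

On both cores shown, the change from ethyl to allyl leaves the two values of each pair indistinguishable, and the two steps cannot be told apart, so within this assay the change carries over from one core to the other as a step inside the scatter. This does not show that the two cores respond identically, since a small real step of either sign on either core would stay hidden in the scatter, and a read-out at one dose says nothing about potency. Two pairs also give no rule beyond compound 1 through compound 4.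

The compounds shown leave open whether any group other than ethyl or allyl at this place would move the number, for instance a longer chain such as butyl, a benzyl group, or a chain ending in an amine or a carboxylic acid. They also leave open what the carbonyl and the oxime each contribute apart from the methoxy groups on the aromatic ring, as compound 1 and compound 3 differ in more than one place and no pair shown separates these features.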